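The compounds below may be only part of what the source reports. "The series", "measured", "known", "first", "only" and "open" are said of these compounds alone.

Measured so far in an ADME assay on Raji cells (Homo sapiens) for cytotoxicity, with a stated time of 72 h; a higher number here means that more compound is needed for the effect, a lower number that less compound is needed:

Compound 1 `Cc1cc(NC(=O)Nc2ccc(C)c(Cl)c2)c2ccccc2n1` sits at the limit of the assay, > 25000 nM.
Compound 2 `Cc1cc(NC(=O)Nc2ccccc2C(F)(F)F)c2ccccc2n1` also sits at the limit, > 25000 nM.
Compound 3 `Cc1ccc(NC(=O)Nc2cc(C)nc3ccccc23)cc1` likewise gives only the limit, > 25000 nM.

Compound 3 therefore stands nowhere that a number can fix: all three measured values are limits, and (the limit of > 25000 nM in this assay, at which 3 of the 3 values shown sit). Among the measured compounds shown here, the only single-point step among them, a step that the two limits leave unreadable from compound 1 to compound 3, is a change of hydrogen in place of chloro on an aromatic carbon whose size cannot be read, since both ends are limits.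

Compound 4 `Cc1cc(NC(=O)Nc2ccc(F)cc2)c2ccccc2n1` is not yet measured. It differs from compound 3 by fluoro in place of methyl on an aromatic carbon. For the measured compounds named here, no measured step touches this exact change, and the one step present, a step that the two limits leave unreadable from compound 1 to compound 3, gives no readable size; so no step beyond the scatter in this assay can be expected in either direction, and a further limit is the likeliest outcome. Compound 4 is estimated at 40000 nM, with a range from 15000 nM to 100000 nM, meaning an expected step that the limit leaves unreadable from compound 3 to compound 4.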

Compound 4, half-maximal effective concentration: > 25000 nM
Compound 4: only a limit was reported; the forecaster's own chance of this, stated with the estimate: 85%; the middle value does not contradict the limit.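

No new step can be read between compound 3 and compound 4, since both give only a limit in this assay: the limit of > 25000 nM in this assay, at which 4 of the 4 values shown sit.

The compounds shown leave open whether fluoro in place of methyl changes anything in this assay, and at what concentration any of these compounds would reach the half-maximal effect.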